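Extending a methyl to ethyl on the amide aryl ring

The source may hold more compounds than are shown below. What is called first, only, known or untested is meant among the compounds shown, and "the series" means these compounds.

Two compounds share one core and differ only in the aromatic group on the amide carbonyl. Compound 1 `COc1cc2ncnc(Nc3ccc(NC(=O)c4ccccc4C)cc3)c2cc1OC` carries a 2-methylphenyl there, and in a functional assay on HepG2 cells (Homo sapiens) for inhibition, read by MTT assay (a lower number here means a stronger inhibitor, a higher number a weaker inhibitor), compound 1 gives 15000 nM. Compound 2 `COc1cc2ncnc(Nc3ccc(NC(=O)c4ccc(C)cc4)cc3)c2cc1OC` carries a 4-methylphenyl instead, and in this assay compound 2 gives 25000 nM. The step from one to the other is a 1.7-fold higher number from compound 1 to compound 2 (0.22 log units; within the scatter), so the two numbers cannot be told apart. Among the compounds with values here, compound 2 thus holds the highest of the two numbers, but its only neighbour sits within the scatter of it.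

Compound 3 `CCc1ccc(C(=O)Nc2ccc(Nc3ncnc4cc(OC)c(OC)cc34)cc2)cc1` is the next variation: methyl in place of hydrogen on a saturated chain carbon bound to an aromatic carbon. Within the data shown here, no measured step addresses this kind of change; the single step in hand, a 1.7-fold higher number from compound 1 to compound 2 (0.22 log units; within the scatter), concerns where the methyl sits on the ring, not its length. With nothing pointing either way, the expected step of no change at the digits printed from compound 2 to compound 3 (within the scatter) is none beyond the scatter. Compound 3 is therefore estimated at 25000 nM in this assay, with a range from 10000 nM to 60000 nM.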

Compound 3, half-maximal inhibitory concentration: 72000 nM
Estimate against measurement, compound 3: 2.9-fold (0.46 log units) below, and the stated range ends below it.
By their numbers in this assay, from the lowest: compounds 1 and 2 (each within the scatter of the next); then compound 3.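

Going from 4-methylphenyl to 4-ethylphenyl on the amide carbonyl gives the first change in this set whose size can be read in this assay: there is a 2.9-fold higher number from compound 2 to compound 3 (0.46 log units; beyond the scatter) and so a weaker inhibitor, even though only one methyl has been added on a saturated chain carbon bound to an aromatic carbon. The 4-ethylphenyl also stands apart from the 2-methylphenyl, with a 4.8-fold higher number from compound 1 to compound 3 (0.68 log units; beyond the scatter), while moving the methyl around the ring gave only a 1.7-fold higher number from compound 1 to compound 2 (0.22 log units; within the scatter) and so no readable difference, which makes this aryl group sensitive to the added carbon in a way the first two compounds could not show. Nothing in the data available here explains why the added methyl weakens inhibition.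

Three compounds cannot show whether the number keeps rising as the chain grows, as it might with a propyl or a longer chain at the same place, or whether this step is a single case. From the compounds shown here alone, it also remains open whether a group of another kind there, such as an amine or a carboxylic acid, would give a stronger or a weaker inhibitor than the ethyl of compound 3.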